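Bromo in place of chloro on compound 2

A few compounds are considered here, and "the series" means these few. Any claim that something is new, unique, unknown or untested is made for them only; others in the source may bear on it.

Compound 1 `O=C(/C=C/c1ccccc1)c1cc(O)ccc1O` gives 61300 nM
Compound 2 `O=C(/C=C/c1ccc(Cl)cc1)c1ccccc1O` gives 48900 nM
Compound 3 `O=C(/C=C/c1ccccc1Cl)c1ccccc1O` gives 7600 nM

All three compounds were measured in a functional assay on WM-115 cells (Homo sapiens) for cytotoxicity, read by MTT assay (a lower number here means a stronger inhibitor, a higher number a weaker inhibitor), and are compared here by that number. The values of compound 1 and compound 2 lie within the usual scatter of repeat measurements, so these two cannot be told apart. Compound 2 gives 48900 nM and compound 3 gives 7600 nM, a gap beyond that scatter, which makes compound 3 the stronger inhibitor of that pair.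

The next compound, compound 4 `O=C(/C=C/c1ccc(Br)cc1)c1ccccc1O`, matches compound 2 except in one place, with bromo in place of chloro on an aromatic carbon. Among the compounds with values here, no two measured compounds here differ in only one place, so the data give no direct measure of a swap like this one. The swap is small, and no change beyond the scatter is expected in this assay. Still, compound 3 (at 7600 nM) also carries a chloro group and sits well apart from compound 2, so the range should stay wide.

The estimated change (a 1.1-fold lower number from compound 2 to compound 4 (0.04 log units; within the scatter)) is expected to stay within the scatter. The estimate for compound 4 is 45000 nM (expected range 20000 nM to 100000 nM).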

Compound 4, half-maximal inhibitory concentration: 50000 nM
Beside the measured number, compound 4's estimate is 1.1-fold (0.05 log units) below it; the measured number falls inside the stated range.
By their numbers in this assay, from the lowest: compound 3; then compounds 2, 4 and 1 (each within the scatter of the next).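

Putting bromo in place of chloro, on an aromatic carbon para to a large group, gives a 1.0-fold higher number from compound 2 to compound 4 (0.01 log units; within the scatter) in this assay, so the two compounds cannot be told apart in this assay. This is the first pair shown that differs in only one place, which turns the earlier expectation for this swap into a direct reading: at this position, the two halogens give the same result within the usual scatter of repeat measurements. Nothing available explains why the two compounds read alike, so this remains an observation about a single pair and offers no cause.

The compounds shown leave open whether this position tolerates groups of other kinds, since a fluoro, a methoxy, an amine or a carboxylic acid in the same place might give a number beyond the scatter. They also leave open whether bromo in place of chloro would read the same way on another aromatic carbon of the shared core, as this single pair speaks only for the position it tests.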